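Acid linker extension on the cyclohexane ring of the series

The source may hold more compounds than are shown below. What is called first, only, known or untested is meant among the compounds shown, and "the series" means these compounds.

Measured so far:
compound 1, `O=C(N[C@H]1CC[C@H](C(=O)O)CC1)[C@H](C1CCCCC1)n1c(-c2ccc(Cl)nc2)nc2cc(F)c(F)cc21` — 9700 nM
compound 2, `COc1ccc(-c2nc3cc(F)c(F)cc3n2[C@H](C(=O)N[C@H]2CC[C@H](C(=O)O)CC2)C2CCCCC2)c(Cl)n1` — 1100 nM

In a functional assay for agonist activity at Bile acid receptor (Homo sapiens), read by a luciferase reporter (a higher number here means that more compound is needed for the effect, a lower number that less compound is needed), compound 1 gives 9700 nM and stands with the highest number of the two measured compounds. For the measured compounds named here, compound 2, `COc1ccc(-c2nc3cc(F)c(F)cc3n2[C@H](C(=O)N[C@H]2CC[C@H](C(=O)O)CC2)C2CCCCC2)c(Cl)n1`, gives 1100 nM in this assay; the single measured step is an 8.8-fold lower number from compound 1 to compound 2 (0.95 log units; beyond the scatter), and it concerns the aromatic ring carried by the shared core, not the acid-bearing ring.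

Compound 3, `O=C(O)CO[C@H]1CC[C@H](NC(=O)[C@H](C2CCCCC2)n2c(-c3ccc(Cl)nc3)nc3cc(F)c(F)cc32)CC1`, is not yet measured. It differs from compound 1 by carboxymethoxy in place of carboxy on a saturated ring carbon. Going by the values given here, no measured step touches this part of the molecule, so the size of the step in this assay cannot be read from compound 2; the step from compound 1 to compound 2 sits elsewhere and gives no guidance on the acid.

With nothing to anchor the change, the expected step is centred near no change, with a wide range in both directions; the expectation for compound 3 is a 1.2-fold lower number from compound 1 to compound 3 (0.08 log units; within the scatter). Compound 3 is therefore estimated at 8000 nM in this assay, between 1500 nM and 40000 nM.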

Compound 3, half-maximal effective concentration: 9900 nM
For compound 3 the middle estimate is 1.2-fold (0.09 log units) below the measured one; measured number inside the range.
By their numbers in this assay, from the lowest: compound 2; then compounds 1 and 3 (each within the scatter of the next).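

In this assay, for the compounds shown here, carboxymethoxy in place of carboxy on a saturated ring carbon gives a 1.0-fold higher number from compound 1 to compound 3 (0.01 log units; within the scatter), the first measured step at the acid-bearing ring. Among the compounds shown, this change leaves the number within the scatter, whereas the change on the aromatic ring gives an 8.8-fold lower number from compound 1 to compound 2 (0.95 log units; beyond the scatter), so only that second position has shown a step beyond the scatter so far. No available evidence bears on the reason for this result.

As far as these compounds go, it remains open whether carboxymethoxy would read the same on the aromatic group of compound 2, as the two changes are seen here only separately on the background of compound 1. Also open, from the compounds shown here alone, is whether a carboxylic acid is required on this ring carbon at all, which a primary amide, a tetrazole or a hydroxymethyl group there could test, as could a longer acid chain for how far the linker can be extended.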